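The compounds below may be only part of what the source reports. "The series", "measured", "known", "first", "only" and "open" are said of these compounds alone.

Measured in a functional assay on HCT-116 cells (Homo sapiens) for antiproliferative activity; a lower number here means a stronger inhibitor, a higher number a weaker inhibitor:
Compound 1 `COc1ccc(-c2snnc2-c2cc(OC)c(OC)c(OC)c2)cc1O`: 3 nM
Compound 2 `COc1cc(-c2nnsc2-c2ccc([N+](=O)[O-])cc2)cc(OC)c1OC`: > 1000 nM, which is a limit of the assay and not a number.
Compound 3 `COc1ccc(-c2snnc2-c2cc(OC)c(OC)c(OC)c2)cc1`: 25 nM

Compound 1 holds the lower of the two actual numbers, and the nearest lies at an 8.3-fold higher number from compound 1 to compound 3 (0.92 log units; beyond the scatter). Compound 4 `COc1ccc(-c2snnc2-c2cc(OC)c(OC)c(OC)c2)cc1N` carries amino in place of hydroxy on an aromatic carbon, ortho to a methoxy group: amino in place of hydroxy on an aromatic carbon. The closest guide is the loss of that hydroxy, an 8.3-fold higher number from compound 1 to compound 3 (0.92 log units; beyond the scatter), which replaces it with hydrogen rather than amino. The step of an at least 40-fold lower number from compound 2 to compound 3 (1.60 log units; beyond the scatter) concerns a methoxy group that compound 4 keeps, so it bears little here. A small rise in this assay is therefore expected, smaller than the loss of the hydroxy and possibly within the scatter. The expected change is a 1.7-fold higher number from compound 1 to compound 4 (0.22 log units; within the scatter). For compound 4 the estimate is 5 nM, with an expected range of 1.5 nM to 20 nM.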

Compound 4, half-maximal inhibitory concentration: 3.7 nM
Beside the measured number, compound 4's estimate is 1.4-fold (0.13 log units) above it; measured number inside the range.
By their numbers in this assay, from the lowest: compounds 1 and 4 (each within the scatter of the next); then compound 3. At a limit, above all of these: compound 2.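

In this assay, amino can stand in place of hydroxy on this aromatic carbon with no change beyond the scatter (a 1.2-fold higher number from compound 1 to compound 4 (0.09 log units; within the scatter)). Compound 3 had shown only what the loss of hydroxy does, and amino in place of that hydrogen gives a clear step back (a 6.8-fold lower number from compound 3 to compound 4 (0.83 log units; beyond the scatter)), so two different groups, each with one hydrogen-bond donor and one acceptor, both give lower numbers than hydrogen. Nothing shown here gives a reason for this. On these data alone, how a methylamino, an acetamido or a fluoro group would read at this position remains open.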